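Swapping a Furan for a Phenyl Beside the Ring Nitrogen

The compounds below may be only part of what the source reports. "The series", "measured", "known", "first", "only" and "open" are said of these compounds alone.

Compound 3 `Oc1ccc(-c2cc(-c3cccc(Cl)c3)nc(-c3ccco3)c2)cc1` gives 8020 nM in a functional assay on HCT-15 cells (Homo sapiens) for cytotoxicity, read by CCK-8 assay and cell counting, with a stated time of 2 days (a higher number here means a weaker inhibitor, a lower number a stronger inhibitor), the lowest of the two numbers recorded; compound 1 `Oc1ccc(-c2cc(-c3cccc(Cl)c3)nc(-c3ccccn3)c2)cc1` gives 28200 nM in this assay, and compound 2 `Oc1ccc(-c2cc(-c3ccncc3)nc(-c3cccc(Cl)c3)c2)cc1` gives "not determined" (no result reported). Going by the values given here, the only step seen so far, a 3.5-fold lower number from compound 1 to compound 3 (0.55 log units; beyond the scatter), came from putting furan-2-yl in place of pyridin-2-yl. Compound 4 `Oc1ccc(-c2cc(-c3ccccc3)nc(-c3cccc(Cl)c3)c2)cc1` differs from compound 3 by phenyl in place of furan-2-yl on an aromatic carbon. Among the compounds with values here, no measured step involves phenyl at this place, so the earlier step gives only a loose guide and no clear direction. The step of a 1.1-fold higher number from compound 3 to compound 4 (0.05 log units; within the scatter) is therefore expected to stay within the scatter. Compound 4 is estimated to give 9000 nM in this assay, with a range from 3000 nM to 30000 nM.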

Compound 4, half-maximal inhibitory concentration: 6100 nM
For compound 4 the middle estimate is 1.5-fold (0.17 log units) above the measured one; low and high end bracket the measured number.
By their numbers in this assay, from the lowest: compounds 4 and 3 (each within the scatter of the next); then compound 1.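

At this place, on an aromatic carbon next to the ring nitrogen, phenyl and furan-2-yl give matching results, with a 1.3-fold lower number from compound 3 to compound 4 (0.12 log units; within the scatter) in this assay. Phenyl also differs clearly from pyridin-2-yl, with a 4.6-fold lower number from compound 1 to compound 4 (0.66 log units; beyond the scatter), so among these three groups pyridin-2-yl alone stands apart. No measurement here explains this difference. Still open, from the compounds shown here alone, is how an amine, a carboxylic acid or a longer alkyl chain at this place would fare. Also open, going by these compounds, is whether the same ranking of groups would hold on a different core.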